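Swapping a Sulfur Chain for Dimethylamino: Expected Response

The compounds below may be only part of what the source reports. "The series", "measured", "known", "first", "only" and "open" are said of these compounds alone.

Compound 1 `COc1ccc([C@H](Nc2cccc3nc(C)ccc23)[C@](O)(CSC)C(F)(F)F)c(Cl)c1F`: 98%
Compound 2 `COc1ccc([C@H](Nc2cccc3nc(C)ccc23)[C@](O)(CN(C)C)C(F)(F)F)c(Cl)c1F`: 77%
Compound 3 `CCSC[C@@](O)([C@@H](Nc1cc(F)cc2[nH]c(=O)ccc12)c1ccc(OC)c(F)c1Cl)C(F)(F)F`: 93%

These three compounds were tested in a functional assay on THP-1 cells (Homo sapiens); a lower number here means a smaller maximal response, a higher number a larger maximal response. Compound 3 stands second highest of the three: compound 1 gives a number within the usual scatter of it, while compound 2 lies beyond the scatter below it. Compound 4 `COc1ccc([C@H](Nc2cc(F)cc3[nH]c(=O)ccc23)[C@](O)(CN(C)C)C(F)(F)F)c(Cl)c1F` differs from compound 3 by dimethylamino in place of ethylsulfanyl on a saturated chain carbon, two bonds along the chain from an oxygen on a saturated carbon. Within the data shown here, one measured step bears on this change: a number 21 percentage points lower from compound 1 to compound 2 (beyond the scatter), where the leaving group was methylsulfanyl rather than ethylsulfanyl. A downward step of similar size is therefore expected here, a number 21 percentage points lower from compound 3 to compound 4 (beyond the scatter), with the longer leaving chain adding some uncertainty. Compound 4 is expected to give 72% in this assay, between 58% and 88%.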

Compound 4, largest response reached (Emax), in percent of the reference or control that the assay uses in the THP-1 assay: 109%
Compound 4: the middle estimate sits 37 percentage points below what was measured; measured number outside the range, above it.
By their numbers in the THP-1 assay, from the lowest: compound 2; then compounds 3 and 1 (each within the scatter of the next); then compound 4.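

In the THP-1 assay the same swap gave a number 16 percentage points higher from compound 3 to compound 4 (beyond the scatter), the opposite direction to a number 21 percentage points lower from compound 1 to compound 2 (beyond the scatter), so at this position the effect of dimethylamino did not carry over between these two pairs, which differ in their cores and in the sulfur chain that leaves. In a physicochemical assay for lipophilicity (a lower number here means a more polar compound, a higher number a more lipophilic compound), compound 3 gives 4.3 and compound 4 gives 4.4, values within the usual scatter of each other. Nothing shown here explains the reversal.

Still open, from the compounds shown here alone, is whether the reversal comes from the core or from the sulfur chain. Going by these compounds, how a ring amine such as morpholine would behave at this position on the core of compound 4 also remains open.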